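Diaryl sulfonamide hydrazides: first antiproliferative readings

The source may report more compounds than this note shows. Statements on the series, on what has been measured and on what is new or still open speak of the compounds shown alone.

Compound 1 `Cc1cccc(NNC(=O)c2ccc(NS(=O)(=O)c3cnc(O)nc3O)cc2)c1`, compound 2 `O=C(NNc1ccccc1Cl)c1cccc(NS(=O)(=O)c2cnc(O)nc2O)c1` and compound 3 `Cc1cccc(NNC(=O)c2ccccc2NS(=O)(=O)c2cnc(O)nc2O)c1` share the sulfonamide core and differ in the arrangement of the hydrazide and its aryl group. In a functional assay on OVCAR-3 cells (Homo sapiens) for antiproliferative activity, read by MTT assay, with a stated time of 24 h (on this read-out higher numbers stand for weaker inhibition and lower numbers for stronger inhibition), compound 1 gives only a limit, > 20000 nM. Compound 3 likewise gives only a limit in this assay, > 20000 nM. Among the measured compounds shown here, compound 2 is the one compound with a measured number, 3350 nM, so it stands alone among the three values; the other two sit at the limit of > 20000 nM in this assay, at which 2 of the 3 values shown sit, and allow no comparison of size.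

Compound 4 `O=C(NNC(=O)c1cccc(NS(=O)(=O)c2cnc(O)nc2O)c1)c1ccc(F)cc1` has not been measured in this assay. It differs from compound 2 by (4-fluorophenyl)carbonyl in place of 2-chlorophenyl on an amine nitrogen. For the measured compounds named here, no measured pair in the set shows the effect of this kind of change, so the step from compound 2 to compound 4 can only be guessed from where compound 2 stands and from the two limits around it. A weakening step beyond the usual scatter is expected for compound 4, a 2.7-fold higher number from compound 2 to compound 4 (0.43 log units; beyond the scatter), with a fair chance that the assay reports only a limit again. The estimated value for compound 4 in this assay is 9000 nM, within a range from 2500 nM to 20000 nM.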

Compound 4, half-maximal inhibitory concentration: > 20000 nM
Compound 4 ended at the assay's limit; the forecaster's own chance of this, stated with the estimate: 45%; middle value at least 2.2-fold (0.34 log units) away from the limit.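

In this assay, among the compounds shown here, (4-fluorophenyl)carbonyl in place of 2-chlorophenyl on an amine nitrogen gives the first readable step, an at least 5.9-fold higher number from compound 2 to compound 4 (0.77 log units; beyond the scatter). Compound 4 gives > 20000 nM, a limit and not a number, so this step has a lower bound but no measured size. Compound 2 remains the only compound with a measured number, and the change at this position moves the series further towards the limit: the limit of > 20000 nM in this assay, at which 3 of the 4 values shown sit.

Still open, as far as these compounds go, is whether the step follows the added carbonyl or the exchange of the chlorine-bearing ring for the fluorine-bearing one; a 4-fluorophenyl or a (2-chlorophenyl)carbonyl group on the same amine nitrogen would separate the two. Also open, from the compounds shown here alone, is how an amine or a carboxylic acid on that aryl ring would read against compound 2.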